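The source may report more compounds than this note shows. Statements on the series, on what has been measured and on what is new or still open speak of the compounds shown alone.

In an ADME assay on a cell-free system (plasma, Mus musculus) for metabolic stability, tested at 5 uM (a lower number here means that the compound disappears faster, a higher number that the compound lasts longer), three compounds with a shared core have been tested so far. Compound 1 `CNS(=O)(=O)c1cc(C(=O)O)ccc1NCCCCCCCC(F)(F)F` gives > 2 h, which is a limit of the assay and not a number. Compound 2 `O=C(O)c1ccc(NCCCCCCCC(F)(F)F)c(S(=O)(=O)N2CCCCC2)c1` gives > 2 h, again a limit. Compound 3 `O=C(O)c1ccc(NCCCCCCCC(F)(F)F)c(S(=O)(=O)NC2CCCC2)c1` gives > 2 h, also a limit. Compound 4 `O=C(O)c1ccc(NCCCCCCCC(F)(F)F)c(S(=O)(=O)NC2CCCCC2)c1` has cyclohexyl in place of cyclopentyl on a sulfonamide nitrogen. The nearest measured changes are a step that the two limits leave unreadable from compound 1 to compound 3, a step that the two limits leave unreadable from compound 2 to compound 3 and a step that the two limits leave unreadable from compound 1 to compound 2, so none gives a readable size. All three compounds share one ceiling, (the limit of > 2 h in this assay, at which 3 of the 3 values shown sit), and no step beyond the usual scatter is expected in this assay. The expected change is a step that the limit leaves unreadable from compound 3 to compound 4. The estimated half-life for compound 4 is 3 h, with an expected range from 2 h to 8 h.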

Compound 4, half-life: > 2 h
Compound 4: a limit, no number; the forecaster's own chance of this, stated with the estimate: 90%; the middle value is on the limit's open side.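

No step can be read among compound 1, compound 2, compound 3 and compound 4 in this assay, because each result is a limit and not a number: the limit of > 2 h in this assay, at which 4 of the 4 values shown sit.

On these data alone, how long each compound actually lasts, and whether the cyclohexyl and cyclopentyl groups differ at all, remains open.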